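From Ethoxycarbonyl to Phenyl: Compound 3 Becomes Compound 4

The compounds below may be only part of what the source reports. "The series", "measured", "known", "first", "only" and "open" are said of these compounds alone.

Three compounds share one core and differ in a single group. In an ADME assay on WI-38 cells (Homo sapiens) for cytotoxicity, read by MTT assay, with a stated time of 72 h (a higher number here means a weaker inhibitor, a lower number a stronger inhibitor), compound 1 (`O=C(CCc1cccc2c1B(O)OC2)Nc1ccccc1`) gives 30000 nM and compound 2 (`O=C(CCc1cccc2c1B(O)OC2)Nc1ccc(I)cc1`) gives 49000 nM as measured numbers. Compound 3 (`CCOC(=O)c1ccc(NC(=O)CCc2cccc3c2B(O)OC3)cc1`) gives > 100000 nM in this assay as a limit of the assay and not a number. Its standing therefore rests on the limit of > 100000 nM in this assay, at which 1 of the 3 values shown sits, and on nothing firmer.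

Compound 4 (`O=C(CCc1cccc2c1B(O)OC2)Nc1ccc(-c2ccccc2)cc1`) carries phenyl in place of ethoxycarbonyl on an aromatic carbon. For the measured compounds named here, no measured step makes this exact swap, so nearby steps must serve. Iodo in place of hydrogen gave a 1.6-fold higher number from compound 1 to compound 2 (0.21 log units; within the scatter) while ethoxycarbonyl in place of hydrogen gave an at least 3.3-fold higher number from compound 1 to compound 3 (0.52 log units; beyond the scatter) and ethoxycarbonyl in place of iodo gave an at least 2.0-fold higher number from compound 2 to compound 3 (0.30 log units; that floor lies within the scatter) as a floor. With ethoxycarbonyl gone, compound 4 is expected to fall back toward compound 1 at 30000 nM and compound 2 at 49000 nM. The estimated step is an at least 2.2-fold lower number from compound 3 to compound 4 (0.34 log units; beyond the scatter) as a modest move toward a lower number in this assay and so toward a stronger inhibitor. For compound 4 the estimate is 45000 nM in this assay with an expected range from 18000 nM to 100000 nM around it.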

Compound 4, half-maximal inhibitory concentration: 32000 nM
Estimate against measurement, compound 4: 1.4-fold (0.15 log units) above; low and high end bracket the measured number.
By their numbers in this assay, from the lowest: compounds 1, 4 and 2 (each within the scatter of the next). At a limit, above all of these: compound 3.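

In this assay, phenyl in place of ethoxycarbonyl on this aromatic carbon gives an at least 3.1-fold lower number from compound 3 to compound 4 (0.49 log units; beyond the scatter), the first measured sign that a group this large at the position need not leave the number out of reach. That step is only a floor, and what compound 3 gives is a limit of the assay and not a number: the limit of > 100000 nM in this assay, at which 1 of the 4 values shown sits.

Phenyl in place of hydrogen gives a 1.1-fold higher number from compound 1 to compound 4 (0.03 log units; within the scatter) and phenyl in place of iodo gives a 1.5-fold lower number from compound 2 to compound 4 (0.19 log units; within the scatter), both within the scatter, so a whole aromatic ring of six carbons at this position reads the same as hydrogen or iodo, something the earlier compounds, with only those two groups and ethoxycarbonyl here, could not show.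

Going by these compounds, what remains open is whether a carboxylic acid or an amine at this position would read like compound 3 or like compound 4. On these data alone, the true value of compound 3 also stays unknown, so the full size of its step to compound 4 cannot be told.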